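A Triazole Aryl Swap on a Weakly Active Terpenoid Ester

The compounds below may be only part of what the source reports. "The series", "measured", "known", "first", "only" and "open" are said of these compounds alone.

Compound 1 `C/C(=C\CC/C(C)=C/CC[C@@H]1[C@@]2(C)CCC(=O)C(C)(C)[C@H]2CC[C@@]1(C)O)CC/C=C(\C)C(=O)OCc1cn(-c2cccc(C)c2)nn1` was tested in a functional assay on A549 cells (Homo sapiens) for antiproliferative activity, read by MTT assay, with a stated time of 48 h; on this read-out higher numbers stand for weaker inhibition and lower numbers for stronger inhibition. In this assay compound 1 gives only a limit, > 150000 nM, not a number. A second analogue, compound 2 `C/C(=C\CC/C(C)=C/CC[C@@H]1[C@@]2(C)CCC(=O)C(C)(C)[C@H]2CC[C@@]1(C)O)CC/C=C(\C)C(=O)OCc1cn([C@@H]2C[C@@H](n3cc(C)c(=O)[nH]c3=O)O[C@H]2CO)nn1`, carries a nucleoside-derived group on the same ring nitrogen instead, and in this assay compound 2 gives 35000 nM. Within the data shown here, no direct step between these two is laid out, so only their two values can be set side by side, and the one for compound 1 is the limit noted at the limit of > 150000 nM in this assay, at which 1 of the 2 values shown sits.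

Compound 3 `C/C(=C\CC/C(C)=C/CC[C@@H]1[C@@]2(C)CCC(=O)C(C)(C)[C@H]2CC[C@@]1(C)O)CC/C=C(\C)C(=O)OCc1cn(-c2ccc(C(C)(C)C)cc2)nn1` is the next analogue. It differs from compound 1 by 4-(tert-butyl)phenyl in place of 3-methylphenyl on an aromatic nitrogen. Among the measured compounds shown here, no measured step covers a change of this kind, so the expectation is for little movement beyond the scatter, with an at least 1.2-fold lower number from compound 1 to compound 3 (0.09 log units; that floor lies within the scatter) as the expected step. For compound 3 the estimate in this assay is 120000 nM, with a likely range from 40000 nM to 300000 nM.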

Compound 3, half-maximal inhibitory concentration: > 150000 nM
Compound 3 was reported as a limit (the forecaster's own chance of this, stated with the estimate: 55%); at least 1.2-fold (0.09 log units) between middle value and limit.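

No step can be read from compound 1 to compound 3, since both stop at the same limit rather than a number: the limit of > 150000 nM in this assay, at which 2 of the 3 values shown sit.

The compounds shown leave open whether 4-(tert-butyl)phenyl and 3-methylphenyl on the aromatic nitrogen differ at all in antiproliferative activity.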